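The source may report more compounds than this note shows. Statements on the series, on what has been measured and on what is new or still open speak of the compounds shown alone.

Working notes on the series in a functional assay on BJAB cells (Homo sapiens) for antiproliferative activity, with a stated time of 4 days; a higher number here means that more compound is needed for the effect, a lower number that less compound is needed.

Compound 1 `Cc1nn(-c2nc(-c3ccc(Cl)c(Cl)c3)c(SC(C)C)s2)c(C(=O)O)c1Cc1ccccc1[N+](=O)[O-]` gives 20000 nM in this assay. Among the three numbers measured so far compound 1 stands second highest. Its nearest neighbour is compound 3 `COc1cc(-c2c(C)nn(-c3nc(-c4ccc(Cl)c(Cl)c4)c(SC(C)C)s3)c2C(=O)O)cc(C(F)(F)F)c1`, which gives 1380 nM; the single-point step a 14-fold lower number from compound 1 to compound 3 (1.16 log units; beyond the scatter) consists of 3-methoxy-5-(trifluoromethyl)phenyl in place of 2-nitrobenzyl on an aromatic carbon. Furthest away is compound 2 `COC(=O)c1c(Cc2ccccc2[N+](=O)[O-])c(C)nn1-c1nc(-c2ccc(Cl)c(Cl)c2)cs1`, which gives 377000 nM; no single-point step links compound 1 and compound 2, so their two values are simply noted side by side.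

The next compound, compound 4 `Cc1nn(-c2nc(-c3ccc(Cl)c(Cl)c3)c(SC(C)C)s2)c(C(=O)O)c1-c1cnn(C)c1`, differs from compound 1 in one place: 1-methyl-1H-pyrazol-4-yl in place of 2-nitrobenzyl on an aromatic carbon. Going by the values given here, the one measured step that bears on this change is the step from compound 1 to compound 3, since there too the 2-nitrobenzyl leaves the same aromatic carbon and an aromatic ring enters, and that step was large in the direction of a lower number. The entering group here, 1-methyl-1H-pyrazol-4-yl, is smaller than the phenyl ring that entered in compound 3, so the same size of step cannot be assumed; a lower number than compound 1 is nonetheless expected, of a size around a 4.0-fold lower number from compound 1 to compound 4 (0.60 log units; beyond the scatter). For compound 4 the expected value is 5000 nM, with a range from 1500 nM to 16000 nM.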

Compound 4, half-maximal effective concentration: 6800 nM
Estimate against measurement, compound 4: 1.4-fold (0.13 log units) below, within the range that was stated.
By their numbers in this assay, from the lowest: compound 3; then compound 4; then compound 1; then compound 2.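

At this aromatic carbon, next to the ring atom that bears a carboxy group and next to the ring atom that bears a methyl group, a second aromatic replacement for 2-nitrobenzyl also lowers the number in this assay: the change gives a 2.9-fold lower number from compound 1 to compound 4 (0.47 log units; beyond the scatter) and so the direction seen with compound 3 is not tied to one entering ring. The identity of the entering ring also counts, for 1-methyl-1H-pyrazol-4-yl in place of 3-methoxy-5-(trifluoromethyl)phenyl gives a 4.9-fold higher number from compound 3 to compound 4 (0.69 log units; beyond the scatter) and the five-membered ring therefore keeps only part of the gain seen with the larger substituted phenyl. No measurement at hand accounts for either step.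

Going by these compounds, it remains open whether a plain phenyl ring, or a phenyl ring carrying only the methoxy or only the trifluoromethyl, would match compound 3 at this carbon. On these data alone, it is equally open whether an amine such as morpholine, with no aromatic ring in the entering group, would keep the lower number or lose it.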